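Pyridyl isomer swap on the biaryl tail

The source may report more compounds than this note shows. Statements on the series, on what has been measured and on what is new or still open speak of the compounds shown alone.

Compound 1 `Cc1ccc(-c2ccc(-c3nc4ccc(S(C)(=O)=O)cc4[nH]3)cc2)cc1` gives > 20000 nM in an assay on isolated protein for inhibition of acyl-CoA desaturase 1 (Rattus norvegicus) (a higher number here means a weaker inhibitor, a lower number a stronger inhibitor), which is a limit of the measurement rather than a number. Compound 2 `Cc1cccc(-c2ccc(-c3nc4ccc(S(C)(=O)=O)cc4[nH]3)cc2)c1` gives 319 nM in this assay. Compound 3 `CS(=O)(=O)c1ccc2nc(-c3ccc(-c4ccncc4)cc3)[nH]c2c1` gives 2470 nM in this assay, the highest of the two numbers; its nearest neighbour is defined by a 7.7-fold higher number from compound 2 to compound 3 (0.89 log units; beyond the scatter).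

Compound 4 `CS(=O)(=O)c1ccc2nc(-c3ccc(-c4ccccn4)cc3)[nH]c2c1` differs from compound 3 only in the tail ring: pyridin-2-yl in place of pyridin-4-yl on an aromatic carbon. Among the compounds with values here, three measured steps bear on this. Relocating a substituent on the tail ring produced an at least 62-fold lower number from compound 1 to compound 2 (1.79 log units; beyond the scatter), a large step. Exchanging the tail ring itself produced an at least 8.0-fold lower number from compound 1 to compound 3 (0.90 log units; beyond the scatter) and a 7.7-fold higher number from compound 2 to compound 3 (0.89 log units; beyond the scatter), both modest. A positional change on the tail ring has therefore moved the number well beyond the scatter before, but its direction for a ring nitrogen is not fixed by the compounds shown. Compound 4 is estimated at 3000 nM, within 500 nM to 15000 nM, which is expected to correspond to a 1.2-fold higher number from compound 3 to compound 4 (0.08 log units; within the scatter).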

Compound 4, half-maximal inhibitory concentration: 1710 nM
Estimate against measurement, compound 4: 1.8-fold (0.24 log units) above; the measured number falls inside the stated range.
By their numbers in this assay, from the lowest: compound 2; then compounds 4 and 3 (each within the scatter of the next). At a limit, above all of these: compound 1.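

Moving the ring nitrogen gives a 1.4-fold lower number from compound 3 to compound 4 (0.16 log units; within the scatter) in this assay and so, unlike the shift of the methyl between compound 1 and compound 2, this positional change on the tail ring does not separate the two compounds. Within the data shown here, neither pyridine isomer matches the 3-methylphenyl tail, as a 5.4-fold higher number from compound 2 to compound 4 (0.73 log units; beyond the scatter) adds a second step beyond the scatter to the one already seen for compound 3. The step of an at least 11-fold lower number from compound 1 to compound 4 (1.06 log units; beyond the scatter) starts from a limit of the assay and gives only a bound: the limit of > 20000 nM in this assay, at which 1 of the 4 values shown sits.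

Going by these compounds, whether pyridin-3-yl would also fall with the other two isomers remains open. Also open, on these data alone, is whether a methyl group on the pyridine ring, or a 3-aminophenyl or 3-methoxyphenyl tail, would approach compound 2.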